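The source may report more compounds than this note shows. Statements on the series, on what has been measured and on what is new or still open speak of the compounds shown alone.

Measured so far in a functional assay on MCF7 cells (Homo sapiens) for antiproliferative activity, read by MTT assay, with a stated time of 48 h; a higher number here means a weaker inhibitor, a lower number a stronger inhibitor:
Compound 1 `Cc1cnc(Nc2ccc(S(N)(=O)=O)cc2)nc1Nc1nc2ccccc2s1`: > 50000 nM, a limit of the assay.
Compound 2 `CS(=O)(=O)c1ccc(Nc2nccc(Nc3nc4ccc(Cl)cc4s3)n2)cc1`: > 50000 nM, also a limit of the assay.
Compound 3 `Cc1cnc(Nc2ccc(S(C)(=O)=O)cc2)nc1Nc1nc2ccc(F)cc2s1`: 3260 nM.

Among the measured compounds shown here, compound 3 thus holds the only number in this assay; the other two values shown sit at the limit of > 50000 nM in this assay, at which 2 of the 3 values shown sit. Compound 4 `Cc1cnc(Nc2ccc(S(C)(=O)=O)cc2)nc1Nc1nc2ccc(Cl)cc2s1` is the next step from compound 3, the change being (chloro in place of fluoro on an aromatic carbon). For the measured compounds named here, no step between two measured compounds of this kind has been measured here, so the data give no direction for this exchange. The expected step is a 1.1-fold lower number from compound 3 to compound 4 (0.04 log units; within the scatter), not beyond the scatter. Compound 4 is therefore expected at 3000 nM in this assay, with a range from 1200 nM to 8000 nM.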

Compound 4, half-maximal inhibitory concentration: 4320 nM
For compound 4 the middle estimate is 1.4-fold (0.16 log units) below the measured one; measured number inside the range.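

In this assay, chloro in place of fluoro on this aromatic carbon gives a 1.3-fold higher number from compound 3 to compound 4 (0.12 log units; within the scatter), so the two halogens cannot be told apart at this position. Methyl in place of hydrogen on an aromatic carbon gives an at least 11-fold lower number from compound 2 to compound 4 (1.06 log units; beyond the scatter), the first change in the series that is beyond the scatter. That step starts from a limit, not a number: the limit of > 50000 nM in this assay, at which 2 of the 4 values shown sit.

On these data alone, the true size of the methyl step stays open. So does whether a methoxy group or an amine on the halogen-bearing carbon would keep the number of compound 4.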